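A few compounds are considered here, and "the series" means these few. Any claim that something is new, unique, unknown or untested is made for them only; others in the source may bear on it.

Of the compounds shown here, three on one shared core have been read in an in vitro ADME assay on microsomes (Homo sapiens) for metabolic stability; on this read-out higher numbers stand for a longer-lived compound and lower numbers for a shorter-lived compound: compound 1 `Cc1c2c(n3c1CCN(C(=O)CN)C[C@@H](C)[C@H](C)Nc1cc-3ccc1C(N)=O)CC(C)(C)CC2=O`, compound 2 `Cc1c2c(n3c1CCN(C(=O)[C@@H](N)C(C)C)C[C@@H](C)[C@H](C)Nc1cc-3ccc1C(N)=O)CC(C)(C)CC2=O` and compound 3 `Cc1c2c(n3c1CCN(C(=O)C(C)(C)N)C[C@@H](C)[C@H](C)Nc1cc-3ccc1C(N)=O)CC(C)(C)CC2=O`. Compound 1 gives > 0.5 h, which is a limit of the assay and not a number. Compound 2 gives 0.133 h and compound 3 gives 0.417 h, so compound 3 holds the higher of the two actual numbers.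

The next compound, compound 4 `Cc1c2c(n3c1CCN(C(=O)[C@H](C)O)C[C@@H](C)[C@H](C)Nc1cc-3ccc1C(N)=O)CC(C)(C)CC2=O`, carries 1-hydroxyethyl in place of 1-amino-1-methylethyl on a carbonyl carbon. Among the compounds with values here, no measured step makes this exchange, but three measured steps change the group at that same carbonyl carbon. The series shows an at least 3.7-fold lower number from compound 1 to compound 2 (0.57 log units; beyond the scatter) and a 3.1-fold higher number from compound 2 to compound 3 (0.50 log units; beyond the scatter), both beyond the scatter, while an at least 1.1-fold lower number from compound 1 to compound 3 (0.07 log units; that floor lies within the scatter) has a floor within the scatter. In all three compounds the group keeps its amine nitrogen, so none of these steps measures a 1-hydroxyethyl group. They give only a scale for the size of a change here, and they do not fix its direction.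

The estimated result is no step beyond the scatter, with a slight lean downward: a 1.4-fold lower number from compound 3 to compound 4 (0.14 log units; within the scatter). Compound 4 is expected to give 0.3 h, with an estimated range from 0.12 h to 0.7 h.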

Compound 4, half-life: 0.25 h
Compound 4: the middle estimate sits 1.2-fold (0.08 log units) above what was measured; low and high end bracket the measured number.
By their numbers in this assay, from the lowest: compounds 2, 4 and 3 (each within the scatter of the next, the first and the last beyond it). At a limit, above all of these: compound 1.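

In this assay, within the data shown here, 1-hydroxyethyl is the first group at this carbonyl carbon that carries no amine nitrogen, and the exchange gives a 1.7-fold lower number from compound 3 to compound 4 (0.22 log units; within the scatter) and a 1.9-fold higher number from compound 2 to compound 4 (0.27 log units; within the scatter). Compound 2 and compound 3 lie beyond the scatter of each other, yet compound 4 lies within the scatter of both, so the readable steps show no clear effect of losing the amine nitrogen at this position. Against compound 1, whose reading is a limit and not a number, the result is an at least 2.0-fold lower number from compound 1 to compound 4 (0.30 log units; that floor lies within the scatter), so the real size of that step cannot be read: the limit of > 0.5 h in this assay, at which 1 of the 4 values shown sits.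

The compounds shown do not separate the loss of the amine nitrogen from the other differences in this exchange, since 1-hydroxyethyl also differs from 1-amino-1-methylethyl in its carbon count and its defined stereocentre. On these data alone, how 1-hydroxy-1-methylethyl, hydroxymethyl or the opposite stereoisomer of 1-hydroxyethyl would read at this carbonyl carbon remains open.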